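Trimming an ethyl to a methyl on the amine nitrogen

The source may hold more compounds than are shown below. What is called first, only, known or untested is meant among the compounds shown, and "the series" means these compounds.

This set of compounds shares one core, a ring carrying an amide to a phenyl group on one side and a substituted nitrogen on the other. Compound 1 `CN(CC1CCCCC1)c1cc(C(=O)Nc2ccccc2)ncn1` carries a methyl and a cyclohexylmethyl on that nitrogen. Compound 2 `CN(c1ccccc1)c1cc(C(=O)Nc2ccccc2)ncn1` carries a methyl and a phenyl there; for compound 2 no result was reported. Compound 3 `CCN(Cc1ccc(Cl)cc1)c1cc(C(=O)Nc2ccccc2)ncn1` carries an ethyl and a chlorobenzyl.

The measure here is an ADME assay on Vero cells (Chlorocebus sabaeus) for cytotoxicity, read by MTT assay; a higher number here means a weaker inhibitor, a lower number a stronger inhibitor. Compound 1 gives 178000 nM. For compound 2 the entry reads "not determined" (no result reported). Compound 3 gives 272000 nM, and this number lies within the usual scatter of the number for compound 1, so the two cannot be told apart.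

Compound 4 `CN(Cc1ccc(Cl)cc1)c1cc(C(=O)Nc2ccccc2)ncn1` differs from compound 3 in one place only: hydrogen in place of methyl on a saturated chain carbon bound to a nitrogen on an aromatic ring. Among the measured compounds shown here, no pair of measured compounds shows this exact change, so its size must be guessed. Both numbers in hand sit far up the scale, and the change is one carbon. Compound 4 is therefore expected to stay in that region, with an expected step of a 1.2-fold lower number from compound 3 to compound 4 (0.07 log units; within the scatter) that does not go beyond the scatter in either direction. Compound 4 is estimated at 230000 nM, with a range from 100000 nM to 500000 nM.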

Compound 4, half-maximal inhibitory concentration: 207000 nM
Beside the measured number, compound 4's estimate is 1.1-fold (0.05 log units) above it, within the range that was stated.
By their numbers in this assay, from the lowest: compounds 1, 4 and 3 (each within the scatter of the next).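

In this assay, among the compounds shown here, hydrogen in place of methyl on a saturated chain carbon bound to a nitrogen on an aromatic ring gives a 1.3-fold lower number from compound 3 to compound 4 (0.12 log units; within the scatter) and so provides the first measured step at this position, where ethyl becomes methyl. That step cannot be told apart from repeat-measurement noise, so the one-carbon trim leaves no readable mark on the result in this set of compounds. Compound 4 also links the two earlier substituent types in a single comparison: 4-chlorophenyl in place of cyclohexyl on that same kind of chain carbon gives a 1.2-fold higher number from compound 1 to compound 4 (0.07 log units; within the scatter) and is likewise too small to read as a real difference, while no measurement here offers an explanation for either step.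

The compounds shown leave open whether a longer chain, such as propyl or butyl, in place of the ethyl would stay within the same narrow band of numbers. They also leave open whether a carboxylic acid or an amine in place of the 4-chlorophenyl would produce a step large enough to stand clear of the scatter.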